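The compounds below may be only part of what the source reports. "The series", "measured", "known", "first", "only" and "open" are said of these compounds alone.

Working notes on the series in a toxicity assay on MDCK cells (Canis lupus familiaris) for cytotoxicity, read by crystal violet staining, with a stated time of 48 h; on this read-out higher numbers stand for lower toxicity in this test and lower numbers for higher toxicity in this test.

Compound 1 `Cc1ccc2cc(C(C)N(Cc3ccc(F)cc3)Cc3ccc(C(C)C)cc3)c(=O)[nH]c2c1` carries a methyl in place of hydrogen on a saturated chain carbon bound to an amine nitrogen and an aromatic carbon, relative to compound 2 `Cc1ccc2cc(CN(Cc3ccc(F)cc3)Cc3ccc(C(C)C)cc3)c(=O)[nH]c2c1`; this is the difference (methyl in place of hydrogen on a saturated chain carbon bound to an amine nitrogen and an aromatic carbon). In this assay compound 2 reports only a limit, > 33000 nM. Compound 1 likewise reports only a limit, > 33000 nM. The step that the two limits leave unreadable from compound 2 to compound 1 therefore cannot be read, since both values sit at the limit of > 33000 nM in this assay, at which 2 of the 3 values shown sit.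

Among the measured compounds shown here, compound 3 `CCc1ccc2[nH]c(=O)c(CN(Cc3ccc(C(C)(C)C)cc3)C(C)c3ccc(F)cc3)cc2c1` is the one compound of the three with a number: in this assay compound 3 gives 2800 nM. How the core of compound 3 differs from that of compound 2 is not broken down here.

Compound 4 `CC(C)c1ccc2[nH]c(=O)c(CN(Cc3ccc(C(C)(C)C)cc3)C(C)c3ccc(F)cc3)cc2c1` is not yet measured. It differs from compound 3 by methyl in place of hydrogen on a saturated chain carbon bound to an aromatic carbon and a saturated chain carbon. This is the same kind of change as that from compound 2 to compound 1, but not the same: there the methyl entered on a saturated chain carbon bound to an amine nitrogen and an aromatic carbon, here it enters on a saturated chain carbon bound to an aromatic carbon and a saturated chain carbon. The earlier step gives no readable size to lean on, and the single methyl is a small addition, so for compound 4 a step of about a 1.1-fold higher number from compound 3 to compound 4 (0.03 log units; within the scatter) from compound 3 is expected. Compound 4 is thus estimated at 3000 nM, with a range from 1000 nM to 10000 nM.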

Compound 4, half-maximal cytotoxic concentration: 13100 nM
Compound 4: middle estimate off by 4.4-fold (0.64 log units), on the low side; measured number above the stated range.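

In this assay, among the compounds shown here, the change from ethyl to isopropyl gives a 4.7-fold higher number from compound 3 to compound 4 (0.67 log units; beyond the scatter), a modest step beyond the scatter towards lower toxicity in this test, and it is the only readable methyl step so far. It shows that a single added methyl can move the number on the core of compound 3, but only for this one place, on a saturated chain carbon bound to an aromatic carbon and a saturated chain carbon. It does not show that the change carries from one core to another, since the other methyl step sits at a different place on a different core and cannot be read: the limit of > 33000 nM in this assay, at which 2 of the 4 values shown sit.

Open, as far as these compounds go, is whether the ethyl to isopropyl change gives a step of similar size on any other core, including one that carries the substituents of compound 2, and whether a methyl on the chain carbon bound to the amine nitrogen moves the number on a core that gives a readable value. Also open, from the compounds shown here alone, is how a longer chain such as n-butyl, a cyclopropyl ring or a carboxylic acid would read in place of the isopropyl of compound 4.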